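Working notes: methyl on the ring amine nitrogen

The source may hold more compounds than are shown below. What is called first, only, known or untested is meant among the compounds shown, and "the series" means these compounds.

Of the compounds shown here, two have numbers so far in a functional assay on cells (Homo sapiens) for cytotoxicity, read by MTT assay, with a stated time of 72 h; a lower number here means a stronger inhibitor, a higher number a weaker inhibitor. Compound 1 `O=C1/C(=C/c2cccnc2)CNC/C1=C\c1cccnc1` gives 30000 nM in this assay. Compound 2 `O=C1/C(=C/c2ccncc2)CNC/C1=C\c1ccncc1` gives 8500 nM in this assay, the lowest of the two numbers; its nearest neighbour is compound 1, whose number is higher by a margin beyond the scatter. Going by the values given here, no step between measured compounds that differ in a single place is available, so the series holds no direct precedent for the change that follows.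

Compound 3 `CN1C/C(=C\c2ccncc2)C(=O)/C(=C/c2ccncc2)C1` has not yet been measured in this assay. It differs from compound 2 in one place: methyl in place of hydrogen on an amine nitrogen in a ring. The rest of the shared core of compound 2 and both attached rings are unchanged.

Among the compounds with values here, with no measured step of this kind to lean on, the expectation for compound 3 is a step of a 1.2-fold lower number from compound 2 to compound 3 (0.08 log units; within the scatter) from compound 2, that is, none beyond the scatter in either direction. Compound 3 is therefore estimated to give about 7000 nM in this assay, with an expected range from 2500 nM to 25000 nM.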

Compound 3, half-maximal inhibitory concentration: 7400 nM
Compound 3: middle estimate off by 1.1-fold (0.02 log units), on the low side; the measured number falls inside the stated range.
By their numbers in this assay, from the lowest: compounds 3 and 2 (each within the scatter of the next); then compound 1.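

In this assay, going by these compounds alone, methyl in place of hydrogen on an amine nitrogen in a ring gives a 1.1-fold lower number from compound 2 to compound 3 (0.06 log units; within the scatter) as the first step that differs in one place, so this position now has a measured precedent where the earlier compounds offered none. The two numbers stand within the scatter of each other, which shows that for this pair, with these attached rings, the hydrogen on that nitrogen is not needed to keep the number in this assay where it stands. Nothing measured here bears on why the two numbers lie so close.

From the compounds shown here alone, one small group on this nitrogen says little about larger ones, and it remains open whether a longer chain such as propyl, a benzyl group or an acetyl group would also stay within the scatter of compound 2. Going by these compounds, it is equally open whether methyl at this position would give a similar step on compound 1, whose attached rings differ from those of compound 2, and whether a carboxylic acid or an amine at the end of a chain on this nitrogen would move the number.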